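The source may hold more compounds than are shown below. What is called first, only, known or untested is meant among the compounds shown, and "the series" means these compounds.

Measured in an ADME assay on Vero cells (Chlorocebus sabaeus) for cytotoxicity, read by MTT assay; a higher number here means that more compound is tolerated, a lower number that less compound is tolerated:
Compound 1 `Cn1nc(C(F)(F)F)cc1C(=O)Nc1ccc(S(=O)(=O)N2CCCCCC2)cc1`: > 300000 nM (a limit, not a number)
Compound 2 `Cn1nc(C(F)(F)F)cc1C(=O)Nc1ccc(S(=O)(=O)N2CCC[C@H]2C(=O)OC(=O)c2ccccc2)cc1`: 100000 nM

Compound 1 stands at the limit of > 300000 nM in this assay, at which 1 of the 2 values shown sits. Compound 3 `Cn1nc(C(F)(F)F)cc1C(=O)Nc1ccc(S(=O)(=O)n2ccc3ccccc32)cc1` carries 1H-indol-1-yl in place of azepan-1-yl on a sulfonyl sulfur. No measured step sizes this change in this assay. For the measured compounds named here, the only numeric guide is compound 2, at 100000 nM. A moderate downward move is expected, an at least 2.5-fold lower number from compound 1 to compound 3 (0.39 log units; beyond the scatter), though a reading that again reaches the limit remains possible. For compound 3 the estimated value is 120000 nM, with an expected range of 40000 nM to 300000 nM.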

Compound 3, half-maximal cytotoxic concentration: 13000 nM
For compound 3 the middle estimate is 9.2-fold (0.97 log units) above the measured one; measured number outside the range, below it.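

In this assay the group on the sulfonyl sulfur is now shown to carry a large effect: 1H-indol-1-yl in place of azepan-1-yl gives an at least 23-fold lower number from compound 1 to compound 3 (1.36 log units; beyond the scatter). That step is a minimum, and compound 1 gives only a limit: the limit of > 300000 nM in this assay, at which 1 of the 3 values shown sits. For the compounds shown here, the single step swaps a seven-membered non-aromatic ring for a fused pair of aromatic rings, so the two features cannot be separated.

Open, from the compounds shown here alone, is whether pyrrol-1-yl, which lacks the six-membered aromatic ring, or piperidin-1-yl on the sulfonyl sulfur would track compound 1 or compound 3.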